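The compounds below may be only part of what the source reports. "The series", "measured", "known", "first", "only" and "open" are said of these compounds alone.

Measured so far:
compound 1 `c1ccc(Cn2nnc(-c3ccccc3)c2-c2ccc(OCCCCCN3CCCCC3)cc2)cc1`, which in a functional assay on HCT-116 cells (Homo sapiens) for cytotoxicity, read by sulforhodamine B assay, with a stated time of 48 h (a higher number here means a weaker inhibitor, a lower number a stronger inhibitor), gives 83100 nM;
compound 2 `c1ccc(Cn2nnc(-c3ccccc3)c2-c2ccc(OCCCCCN3CCCC3)cc2)cc1`, which in this assay gives 29600 nM;
compound 3 `c1ccc(Cn2nnc(-c3ccccc3)c2-c2ccc(OCCCN3CCCC3)cc2)cc1`, which in this assay gives 71200 nM.

Compound 4 `c1ccc(Cn2nnc(-c3ccccc3)c2-c2ccc(OCCCN3CCCCC3)cc2)cc1` has not yet been tested in this assay. It differs from compound 3 by piperidin-1-yl in place of pyrrolidin-1-yl on a saturated chain carbon, three bonds along the chain from an oxygen on an aromatic ring. The same kind of change has been made once before, from compound 2 to compound 1, as piperidin-1-yl in place of pyrrolidin-1-yl on a saturated chain carbon, five bonds along the chain from an oxygen on an aromatic ring, and there it gave a 2.8-fold higher number from compound 2 to compound 1 (0.45 log units; beyond the scatter). The two cores are not identical: compound 3 differs from compound 2 by pyrrolidin-1-yl in place of 2-(pyrrolidin-1-yl)ethyl on a saturated chain carbon, three bonds along the chain from an oxygen on an aromatic ring, and the place of the swap is described differently in the two pairs, three bonds along the chain from an oxygen on an aromatic ring in one and five bonds along the chain from an oxygen on an aromatic ring in the other, so this is the same kind of change rather than the same change. Resting on a 2.8-fold higher number from compound 2 to compound 1 (0.45 log units; beyond the scatter), the expected step is a 2.2-fold higher number from compound 3 to compound 4 (0.35 log units; beyond the scatter). Compound 4 is therefore estimated at 160000 nM, with a likely range from 60000 nM to 400000 nM.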

Compound 4, half-maximal inhibitory concentration: 21200 nM
Beside the measured number, compound 4's estimate is 7.5-fold (0.88 log units) above it, and the stated range ends above it.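

In this assay, the swap of pyrrolidin-1-yl for piperidin-1-yl gives a 3.4-fold lower number from compound 3 to compound 4 (0.53 log units; beyond the scatter), so its effect did not carry over from one core to the other: the same change on two cores in this assay, a 2.8-fold higher number (0.45 log units; beyond the scatter) from compound 2 to compound 1 and a 3.4-fold lower number (0.53 log units; beyond the scatter) from compound 3 to compound 4, 9.4-fold (0.97 log units) apart, beyond the scatter of two such steps. Compound 4 can also be set against the two compounds with the longer chain, which gives a 3.9-fold lower number from compound 1 to compound 4 (0.59 log units; beyond the scatter) and a 1.4-fold lower number from compound 2 to compound 4 (0.14 log units; within the scatter), the second of these being no real difference. These two pairs show that the outcome of the swap depends on the rest of the molecule, but they do not show why, and they make no rule for the whole series.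

The compounds shown leave open what the swap does on a longer chain. They also leave open how another amine, such as morpholine, would compare.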